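Thiophen-3-yl for pyridin-3-yl: expected cytotoxicity step

The compounds below may be only part of what the source reports. "The series", "measured", "known", "first", "only" and "open" are said of these compounds alone.

Compound 2 `Oc1ccc(-c2cc(-c3ccc(Cl)cc3)nc(-c3cccnc3)c2)cc1` gives 22800 nM in a functional assay on DU-145 cells (Homo sapiens) for cytotoxicity, read by CCK-8 assay and cell counting, with a stated time of 2 days; on this read-out higher numbers stand for weaker inhibition and lower numbers for stronger inhibition. Compound 3 `Oc1cccc(-c2cc(-c3ccc(Cl)cc3)nc(-c3cccnc3)c2)c1`, which carries 3-hydroxyphenyl in place of 4-hydroxyphenyl on an aromatic carbon, gives 26800 nM in this assay; the step of a 1.2-fold higher number from compound 2 to compound 3 (0.07 log units; within the scatter) lies within the scatter, so these two numbers cannot be ordered. Compound 1 `Oc1ccc(-c2cc(-c3ccccn3)nc(-c3ccccc3Cl)c2)cc1` stands at "not determined" (no result reported) in this assay, so no number is in hand for it. Of the two numbers in hand, compound 2 holds the lower one, with compound 3 sitting within the scatter of it.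

Compound 4 `Oc1ccc(-c2cc(-c3ccc(Cl)cc3)nc(-c3ccsc3)c2)cc1` differs from compound 2 in one place: thiophen-3-yl in place of pyridin-3-yl on an aromatic carbon. Among the compounds with values here, no measured step touches this position of the shared core; the only step in hand, a 1.2-fold higher number from compound 2 to compound 3 (0.07 log units; within the scatter), concerns the hydroxyphenyl group and stayed within the scatter. Nothing in the series therefore points to a direction for the change in this assay, and the expectation is a step of no more than the scatter, estimated as a 1.1-fold lower number from compound 2 to compound 4 (0.06 log units; within the scatter). As far as these compounds go, compound 4 is expected to give 20000 nM in this assay, with a range from 7000 nM to 60000 nM; the wide range reflects that this swap is untested.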

Compound 4, half-maximal inhibitory concentration: 6940 nM
Compound 4: the middle estimate sits 2.9-fold (0.46 log units) above what was measured, and the stated range ends above it.
By their numbers in this assay, from the lowest: compound 4; then compounds 2 and 3 (each within the scatter of the next).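

Within the data shown here, the position next to the ring nitrogen on the shared core, meta to both the 4-chlorophenyl and the 4-hydroxyphenyl groups, is the first place where a single change moves the number beyond the scatter in this assay: thiophen-3-yl in place of pyridin-3-yl gives a 3.3-fold lower number from compound 2 to compound 4 (0.52 log units; beyond the scatter), while the one earlier step, at the hydroxyphenyl group, gave a 1.2-fold higher number from compound 2 to compound 3 (0.07 log units; within the scatter). The change swaps a six-membered aromatic ring holding a nitrogen for a five-membered aromatic ring holding a sulfur, while the counts of hydrogen-bond donors and acceptors and the net charge printed for the two groups stay the same, so those counts do not separate this pair. No measurement at hand accounts for the lower number.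

The compounds shown leave open whether the step follows the loss of the ring nitrogen, the smaller ring or the sulfur; phenyl, furan-3-yl or thiophen-2-yl at this position would begin to separate these. As far as these compounds go, it also remains open whether the step holds with 3-hydroxyphenyl in place of 4-hydroxyphenyl, and how far it extends to the other cell lines.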